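Bromo in place of iodo: working notes on compound 3

The source may report more compounds than this note shows. Statements on the series, on what has been measured and on what is new or still open speak of the compounds shown alone.

Measured in an in vivo ADME assay on the whole organism for pharmacokinetics, with Rattus norvegicus as the target, at a dose of 5 mg/kg by the oral route (on this read-out higher numbers stand for higher oral bioavailability and lower numbers for lower oral bioavailability), so far:
- compound 1 `O=C(NOC[C@H](O)CO)c1ccc2cnsc2c1Nc1ccc(I)cc1F` gives 51%
- compound 2 `O=C(NOCCO)c1ccc2[nH]ncc2c1Nc1ccc(I)cc1F` gives 21%

Compound 2 at 21% is the lower of the two numbers, and the gap to compound 1 at 51% lies beyond the scatter. The next compound is compound 3 `O=C(NOCCO)c1ccc2[nH]ncc2c1Nc1ccc(Br)cc1F`, not yet measured in this assay and set apart from compound 2 by one change: bromo in place of iodo on an aromatic carbon. This puts bromo in place of iodo on an aromatic carbon, para to a large group and meta to a fluoro group. Among the compounds with values here, no measured pair differs in one place only, so nothing measured yet shows the size of this exchange. The expectation rests on compound 2 at 21% and on the structural change alone. The expected step, a number 3 percentage points higher from compound 2 to compound 3 (within the scatter), is estimated to stay within the scatter, with no firm direction. In this assay the estimate for compound 3 is 24%, with an expected range from 10% to 42% as the working bracket.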

Compound 3, oral bioavailability: 34%
Compound 3: the middle estimate sits 10 percentage points below what was measured; low and high end bracket the measured number.
By their numbers in this assay, from the lowest: compound 2; then compound 3; then compound 1.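

Within the data shown here, the first pair that differs in one place gives this position a measured size: in this assay, bromo in place of iodo on an aromatic carbon, para to a large group and meta to a fluoro group, gives a number 13 percentage points higher from compound 2 to compound 3 (beyond the scatter). The exchange is one heavy atom for one heavy atom, with no hydrogen-bond donors, hydrogen-bond acceptors or net charge on either side, and the 2-fluoro-4-iodophenyl to 4-bromo-2-fluorophenyl change alone is still enough to give a modest step on this read-out. This is a single pair on a single core, and nothing measured here accounts for the step.

On these data alone, it remains open whether the same exchange gives a step of similar size and direction on the core of compound 1, which differs from compound 2 in more than one place. Also open, as far as these compounds go, is how a chloro group, a methyl group, a nitrile or an amine would compare with bromo and iodo at this position, and whether the trend from iodo to bromo extends to any of them.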